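From methylamino to amino under an assay limit

A few compounds are considered here, and "the series" means these few. Any claim that something is new, unique, unknown or untested is made for them only; others in the source may bear on it.

Measured in a functional assay on HepG2 cells (Homo sapiens) for cytotoxicity, read by XTT assay, with a stated time of 6 days; on this read-out higher numbers stand for weaker inhibition and lower numbers for stronger inhibition:
Compound 1 `CN(C)c1ncnc2[nH]cc(Sc3cccs3)c12` gives > 25000 nM (a limit)
Compound 2 `CNc1ncnc2[nH]cc(Sc3cccs3)c12` gives > 25000 nM (a limit)

In this assay compound 2 stands at > 25000 nM as a limit and not a number. Compound 3 `Nc1ncnc2[nH]cc(Sc3cccs3)c12` has yet to be measured. It departs from compound 2 by hydrogen in place of methyl on a nitrogen on an aromatic ring with hydrogen in place of methyl on a nitrogen on an aromatic ring, methylamino to amino. Going by the values given here, one measured step bears on this change, the same exchange made one methyl earlier: a step that the two limits leave unreadable from compound 1 to compound 2 is all it offers. Both measured compounds stand at one limit, the limit of > 25000 nM in this assay, at which 2 of the 2 values shown sit, and no size can be read from it. Because a step that the two limits leave unreadable from compound 1 to compound 2 gives no size, no change beyond the scatter is expected in this assay and no direction can be named. The expected step, as an estimate, is a number no higher from compound 2 to compound 3 (the limit leaves the size open) and no more can be claimed. Compound 3 is expected at 25000 nM with an estimated range of 10000 nM to 50000 nM.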

Compound 3, half-maximal inhibitory concentration: > 25000 nM
Compound 3 gave a limit, no number; the forecaster's own chance of this, stated with the estimate: 80%; the middle value lies on the limit itself.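

In this assay compound 3 gives > 25000 nM as a limit and not a number. Going by these compounds alone, no new step among compound 1, compound 2 and compound 3 can be read: the limit of > 25000 nM in this assay, at which 3 of the 3 values shown sit. The compounds shown leave open what actual half-maximal inhibitory concentration each has, and so whether removing either methyl changes it.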